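The source may hold more compounds than are shown below. What is called first, only, known or untested is meant among the compounds shown, and "the series" means these compounds.

Compound 1 `Cc1cccc(Cn2c(CN3CCN(C(=O)CC(C)C)CC3)nc3ccccc32)c1` gives 71.4% in an assay on isolated protein for inhibition of aldehyde dehydrogenase 1A1 (Homo sapiens), read by spectrophotometry, tested at 10 uM; on this read-out higher numbers stand for more inhibition at the one concentration tested (going by the name of the read-out) and lower numbers for less inhibition. Compound 2 `CC(C)CCn1c(OC2CCN(C(=O)c3ccco3)CC2)nc2ccccc21` gives 30.8% in this assay. Compound 3 `O=C(C1CC1)N1CCN(Cc2nc3ccccc3n2Cc2ccc(F)cc2)CC1` gives 32.7% in this assay.

Compound 1 stands highest of the three numbers. Its nearest neighbour is compound 3, whose value lies well below it, beyond the scatter; the furthest is compound 2, lower still. For the measured compounds named here, both of those compounds differ from compound 1 in more than one place, so none of these gaps can be read as the effect of a single change, and no step between measured compounds that differ in one place is available.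

Compound 4 `Cc1cccc(Cn2c(CN3CCN(C(=O)c4cccs4)CC3)nc3ccccc32)c1` is the unmeasured partner of compound 1. The difference between them is thiophen-2-yl in place of isobutyl on a carbonyl carbon. Nothing measured here shows what this particular exchange on a carbonyl carbon does, since the two lower compounds carry several changes at once. The expected step from compound 1 to compound 4 in this assay is therefore a modest downward one, estimated at about the edge of the usual scatter, a number 13.4 percentage points lower from compound 1 to compound 4 (beyond the scatter). Compound 4 is accordingly expected to give around 58% in this assay, with an estimated range from 32% to 82%.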

Compound 4, a percentage reported as inhibition, at one concentration (the size of the read-out at that concentration, not a potency): 60.8%
Beside the measured number, compound 4's estimate is 2.8 percentage points below it, within the range that was stated.
By their numbers in this assay, from the lowest: compounds 2 and 3 (each within the scatter of the next); then compound 4; then compound 1.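

For the compounds shown here, this is the first single change that can be read in this assay: with the rest of compound 1 kept, thiophen-2-yl in place of isobutyl on a carbonyl carbon gives a number 10.6 percentage points lower from compound 1 to compound 4 (beyond the scatter), so this position does respond to the exchange. The response is modest, and the open chain can give way to a five-membered aromatic ring with much of the inhibition kept, since compound 4 still gives 60.8% at the one concentration tested. Nothing available accounts for the size or the direction of this step.

Left open is how the same carbonyl carbon would respond to a phenyl ring, a longer alkyl chain such as n-hexyl, or a dimethylamino group, and whether the exchange would give a step of similar size on a different core. The gaps to compound 2 and compound 3 cannot be read as steps, each of those compounds differing from the others in more than one place.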